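Ethyl to phenyl on a saturated chain

The source may report more compounds than this note shows. Statements on the series, on what has been measured and on what is new or still open speak of the compounds shown alone.

Three compounds sharing one core, differing only in a saturated chain, have numbers in an ADME assay on MT4 cells (Homo sapiens) for cytotoxicity, read by MTT assay; on this read-out higher numbers stand for lower toxicity in this test and lower numbers for higher toxicity in this test. Compound 1 `CCCCCCC1C(=O)N(O)C(=O)c2ccccc21` gives 4400 nM, compound 2 `CCCC1C(=O)N(O)C(=O)c2ccccc21` gives 25400 nM, and compound 3 `CCCCC1C(=O)N(O)C(=O)c2ccccc21` gives 25400 nM. Compound 3 is therefore level with compound 2, and together they hold the highest of the three numbers.

Compound 4 `O=C1c2ccccc2C(CCc2ccccc2)C(=O)N1O` differs from compound 3 in one place: phenyl in place of ethyl on a saturated chain carbon, two bonds along the chain from a saturated ring carbon.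

Within the data shown here, no measured compound carries a ring on this chain, so the chain steps are only rough guides. One small change gave no change at the digits printed from compound 2 to compound 3 (within the scatter), whereas the larger chain change gave a 5.8-fold higher number from compound 1 to compound 3 (0.76 log units; beyond the scatter), and the same size appears in a 5.8-fold higher number from compound 1 to compound 2 (0.76 log units; beyond the scatter). Compound 4 gains size, so a modest move towards compound 1 seems likeliest. The expected step is a 2.1-fold lower number from compound 3 to compound 4 (0.33 log units; beyond the scatter). Compound 4 is estimated at 12000 nM, with an expected range of 4000 nM to 30000 nM.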

Compound 4, half-maximal cytotoxic concentration: 30000 nM
Compound 4: middle estimate off by 2.5-fold (0.40 log units), on the low side, within the range that was stated.
By their numbers in this assay, from the lowest: compound 1; then compounds 2, 3 and 4 (each within the scatter of the next).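

On this chain carbon, phenyl in place of ethyl is taken up without a move in the number in this assay (a 1.2-fold higher number from compound 3 to compound 4 (0.07 log units; within the scatter)), and phenyl in place of methyl reads the same way (a 1.2-fold higher number from compound 2 to compound 4 (0.07 log units; within the scatter)). So an aromatic ring of six carbons on this chain leaves compound 4 level with the two short-chain compounds. Only compound 1 stands apart, as phenyl in place of butyl shows (a 6.8-fold higher number from compound 1 to compound 4 (0.83 log units; beyond the scatter)), so extra heavy atoms alone do not bring the number down across these four compounds, and nothing shown here explains the gap.

Still open, going by these compounds, is whether an amine or a carboxylic acid on the phenyl ring would stay at this level. A longer chain ending in phenyl might instead come closer to compound 1.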